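Shrinking the ring: from compound 3 to compound 4

A few compounds are considered here, and "the series" means these few. Any claim that something is new, unique, unknown or untested is made for them only; others in the source may bear on it.

In a toxicity assay on Huh-7.5 cells (Homo sapiens) for inhibition, read by MTT assay, with a stated time of 96 h (on this read-out lower numbers stand for higher toxicity in this test and higher numbers for lower toxicity in this test), compound 3 `CN(C)C1CCN(Cc2ccc(NC(=O)c3ccc(OCCCCl)c([N+](=O)[O-])c3)cc2C(F)(F)F)CC1` gives 5500 nM, and compound 2 `CN1CCN(Cc2ccc(NC(=O)c3ccc(OCCCCl)c([N+](=O)[O-])c3)cc2C(F)(F)F)CC1` gives 6800 nM. Those two values sit within the scatter of each other: a 1.2-fold lower number from compound 2 to compound 3 (0.09 log units; within the scatter).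

Compound 1 `O=C(Nc1ccc(CN2CC(C(=O)O)C2)c(C(F)(F)F)c1)c1ccc(OCCCCl)c([N+](=O)[O-])c1` reaches only a limit of the assay, > 200000 nM.

Compound 4 `CN(C)C1CN(Cc2ccc(NC(=O)c3ccc(OCCCCl)c([N+](=O)[O-])c3)cc2C(F)(F)F)C1` carries one change: 3-(dimethylamino)azetidin-1-yl in place of 4-(dimethylamino)piperidin-1-yl on a saturated chain carbon bound to an aromatic carbon. The large steps of an at least 29-fold lower number from compound 1 to compound 2 (1.46 log units; beyond the scatter) and an at least 36-fold lower number from compound 1 to compound 3 (1.56 log units; beyond the scatter) both remove a 3-carboxyazetidin-1-yl group. Compound 4 has a four-membered ring too, but with the dimethylamino group of compound 3 and no carboxy group, so those steps cannot separate ring from carboxy. Only a small move toward a higher number is expected: a 1.6-fold higher number from compound 3 to compound 4 (0.21 log units; within the scatter). Compound 4 is estimated at 9000 nM, with an expected range of 4000 nM to 30000 nM.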

Compound 4, half-maximal cytotoxic concentration: 7800 nM
For compound 4 the middle estimate is 1.2-fold (0.06 log units) above the measured one; the range from low to high includes it.
By their numbers in this assay, from the lowest: compounds 3, 2 and 4 (each within the scatter of the next). At a limit, above all of these: compound 1.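

In this assay, replacing the six-membered ring with the four-membered ring stays within the scatter: a 1.4-fold higher number from compound 3 to compound 4 (0.15 log units; within the scatter), and a 1.1-fold higher number from compound 2 to compound 4 (0.06 log units; within the scatter). With the four-membered ring kept, dimethylamino in place of carboxy gives an at least 25-fold lower number from compound 1 to compound 4 (1.40 log units; beyond the scatter), so the large steps go with the carboxy group, not with ring size. The value of compound 1 is a limit, not a number: the limit of > 200000 nM in this assay, at which 1 of the 4 values shown sits.

Still open, on these data alone, is whether a carboxylic acid on the six-membered ring also reaches that limit. A primary amine in place of dimethylamino on the four-membered ring is also untested among these compounds.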